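This account rests on a few compounds, and the source may have more. Where it says the series, first, only, none or still open, it means among the compounds named here.

Working notes on the series around compound 1 `Cc1cccc([C@@H](O)C(=O)N2N=CC[C@H]2C(=O)NCc2cc(Cl)ccc2-n2cnnn2)c1`, read in an ADME assay on liver for metabolic stability, with Liver microsome (Homo sapiens) as the target, read by LC-MS, using microsomes; on this read-out higher numbers stand for fast clearance and lower numbers for slow clearance. Compound 1 gives < 12 mL.min-1.g-1, which is a limit of the assay and not a number. Compound 3 `CC(C)(C)[C@@H](O)C(=O)N1CC(=O)C[C@H]1C(=O)NCc1cc(Cl)ccc1-n1cnnn1` likewise stands at a limit, < 12 mL.min-1.g-1. Compound 2 `CC(C)(C)C[C@@H](O)C(=O)N1CC[C@@H]2C[C@@]21C(=O)NCc1cc(Cl)ccc1-n1cnnn1` gives a number, 27 mL.min-1.g-1. Given (the limit of < 12 mL.min-1.g-1 in this assay, at which 2 of the 3 values shown sit), compound 1 stands among the slower values of this set. Compound 4 `O=C(NCc1cc(Cl)ccc1-n1cnnn1)[C@@H]1CC=NN1C(=O)[C@H](O)Cc1ccccc1` is not yet measured. It differs from compound 1 by benzyl in place of 3-methylphenyl on a saturated chain carbon bound to a carbonyl carbon and an oxygen on a saturated carbon. Within the data shown here, no measured pair in the set shows this kind of change, so no step beyond the usual scatter is expected in this assay, in either direction. Compound 4 is expected to give 13 mL.min-1.g-1, with a range of 5 mL.min-1.g-1 to 30 mL.min-1.g-1. The step expected is an at least 1.0-fold higher number from compound 1 to compound 4 (0.03 log units; that floor lies within the scatter).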

Compound 4, intrinsic clearance in microsomes: < 12 mL.min-1.g-1
Compound 4: no number, only a limit; the forecaster's own chance of this, stated with the estimate: 45%; middle value at least 1.0-fold (0.03 log units) from the limit.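

Compound 1 and compound 4 both sit at a limit of this assay, so no step between them can be read: the limit of < 12 mL.min-1.g-1 in this assay, at which 3 of the 4 values shown sit.

The compounds shown leave open whether benzyl in place of 3-methylphenyl changes clearance at all.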